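A methoxy in place of a methyl on compound 2

The source may report more compounds than this note shows. Statements on the series, on what has been measured and on what is new or still open speak of the compounds shown alone.

compound 1 `Cc1ccc(C(=O)CCN2CCN(c3ccc(C(F)(F)F)cc3)CC2)cc1`: 140000 nM
compound 2 `Cc1ccc(C(=O)CCN2CCN(c3ccc(Cl)cc3)CC2)cc1`: 184000 nM
compound 3 `COc1ccc(C(=O)CCN2CCN(c3ccc(Cl)cc3)CC2)cc1`: not yet measured

In an ADME assay on Vero cells (Chlorocebus sabaeus) for cytotoxicity, read by resazurin assay, with a stated time of 72 h (a higher number here means a weaker inhibitor, a lower number a stronger inhibitor), compound 2 gives 184000 nM, which lies within the scatter of compound 1 at 140000 nM. With only these two values, its standing says little. The move to compound 3 is methoxy in place of methyl on an aromatic carbon, (methoxy in place of methyl on an aromatic carbon). For the measured compounds named here, the one measured step, a 1.3-fold higher number from compound 1 to compound 2 (0.12 log units; within the scatter), is chloro in place of trifluoromethyl on an aromatic carbon and stays within the scatter. It leaves the methyl untouched, so no measured step tests this change directly, and the data give no reason to expect a shift beyond the scatter in this assay. The expected step is a 1.2-fold lower number from compound 2 to compound 3 (0.06 log units; within the scatter). Compound 3 is estimated at 160000 nM, with an expected range from 70000 nM to 350000 nM.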

Compound 3, half-maximal inhibitory concentration: 300000 nM
Beside the measured number, compound 3's estimate is 1.9-fold (0.27 log units) below it, and the stated range covers the measured number.
By their numbers in this assay, from the lowest: compounds 1, 2 and 3 (each within the scatter of the next, the first and the last beyond it).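

In this assay methoxy in place of methyl gives a 1.6-fold higher number from compound 2 to compound 3 (0.21 log units; within the scatter) at a place the earlier pair left unchanged, an aromatic carbon para to a large group. The first change read at this place, which brings in an oxygen and a hydrogen-bond acceptor, thus stays within the scatter, as did the swap of trifluoromethyl for chloro elsewhere on the shared core. Nothing measured here explains the size of this step.

Going by these compounds, whether an amine or a carboxylic acid on this aromatic carbon, or a longer chain such as ethoxy, would carry the number beyond the scatter remains open. Also open, on these data alone, is whether methoxy in place of methyl would read the same with trifluoromethyl in place of the chloro.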